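Swapping 2-aminocyclohexyl for an open amino alcohol chain

The compounds below may be only part of what the source reports. "The series", "measured", "known", "first", "only" and "open" are said of these compounds alone.

In a functional assay on HCT-116 cells (Homo sapiens) for cytotoxicity, read by fluorescence, with a stated time of 72 h (on this read-out higher numbers stand for weaker inhibition and lower numbers for stronger inhibition), three compounds built on a shared core have been measured so far. Compound 1 `CC(C)c1n[nH]c2c(NCc3ccc(-c4ccccn4)cc3)nc(NCCO)nc12` carries 2-hydroxyethyl on a nitrogen on an aromatic ring and gives 27 nM in this test. Compound 2 `CC(C)c1n[nH]c2c(NCc3ccc(-c4ccccn4)cc3)nc(NCC(C)(C)O)nc12` carries 2-hydroxy-2-methylpropyl at that place and gives 85 nM on the same read-out. Compound 3 `CC(C)c1n[nH]c2c(NCc3ccc(-c4ccccn4)cc3)nc(N[C@@H]3CCCC[C@H]3N)nc12` carries 2-aminocyclohexyl and stands highest of the three at 427 nM which marks the weakest inhibition of the set.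

Compound 4 `CC(C)c1n[nH]c2c(NCc3ccc(-c4ccccn4)cc3)nc(NCC(N)CO)nc12` remains unmeasured. It has 2-amino-3-hydroxypropyl in place of 2-aminocyclohexyl on a nitrogen on an aromatic ring. The step of a 16-fold higher number from compound 1 to compound 3 (1.20 log units; beyond the scatter) is large, the step of a 5.0-fold higher number from compound 2 to compound 3 (0.70 log units; beyond the scatter) is modest, and the smaller step of a 3.1-fold higher number from compound 1 to compound 2 (0.50 log units; beyond the scatter) is also modest. Compound 4 has no ring in this chain and a hydroxy group, as compound 1 and compound 2 do, yet it keeps an amino group, as compound 3 does. No open chain with an amino group has been measured, so the range stays wide. A modest step toward lower numbers is expected in this assay about the size of a 5.0-fold higher number from compound 2 to compound 3 (0.70 log units; beyond the scatter) read in reverse. The expected change is a 5.3-fold lower number from compound 3 to compound 4 (0.73 log units; beyond the scatter) on this estimate. Compound 4 is estimated at 80 nM with an expected range from 25 nM to 260 nM in this test.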

Compound 4, half-maximal inhibitory concentration: 781 nM
For compound 4 the middle estimate is 9.8-fold (0.99 log units) below the measured one, and the stated range ends below it.
By their numbers in this assay, from the lowest: compound 1; then compound 2; then compounds 3 and 4 (each within the scatter of the next).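

In this assay, the ring of 2-aminocyclohexyl proved unnecessary for a high number: the open 2-amino-3-hydroxypropyl chain left the read-out within the scatter, with a 1.8-fold higher number from compound 3 to compound 4 (0.26 log units; within the scatter). The open chains without an amino group stand clearly apart, with a 9.2-fold higher number from compound 2 to compound 4 (0.96 log units; beyond the scatter) and a 29-fold higher number from compound 1 to compound 4 (1.46 log units; beyond the scatter), so among these four compounds both groups that carry an amino group give the higher numbers, and no compound goes against this, whether the amino group sits on a ring or on an open chain. Nothing available here accounts for why the numbers fall this way.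

The compounds shown do not separate the amino group from the rest of the chain, since compound 4 differs from compound 1 by a whole 1-amino-2-hydroxyethyl group rather than by the amino group alone. A 2-aminoethyl chain with no hydroxy group, a 2,3-dihydroxypropyl chain with a hydroxy group where compound 4 has its amino group, or an acetamide in place of that amino group would each bear on this question.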